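The source may report more compounds than this note shows. Statements on the series, on what has been measured and on what is new or still open speak of the compounds shown alone.

Going by the values given here, compound 2, `Cc1ccc2[nH]c(C(=O)N[C@H]3CN(S(=O)(=O)c4cnccn4)C[C@@H]3C(=O)NCCN(C)C)cc2c1`, is one of two compounds measured in an ADME assay on cells (Hepatocyte, Rattus norvegicus) for metabolic stability; on this read-out lower numbers stand for slow clearance and higher numbers for fast clearance. Compound 2 gives 12 uL/min, the higher of the two numbers; compound 1, `Cc1ccc2[nH]c(C(=O)N[C@H]3CN(S(=O)(=O)c4ccnnc4)C[C@@H]3C(=O)NCCN(C)C)cc2c1`, gives 2 uL/min. Among the compounds with values here, the only measured step, a 6.0-fold higher number from compound 1 to compound 2 (0.78 log units; beyond the scatter), exchanges the ring on the sulfonyl sulfur, and the step considered here does the same. Compound 3, `Cc1ccc2[nH]c(C(=O)N[C@H]3CN(S(=O)(=O)c4ccnc(C)c4)C[C@@H]3C(=O)NCCN(C)C)cc2c1`, differs from compound 2 at that place: 2-methylpyridin-4-yl in place of pyrazin-2-yl on a sulfonyl sulfur. The measured step shows that swapping the ring on the sulfonyl sulfur can shift the number by a modest amount beyond the scatter, but with a single step in hand the direction for a new ring cannot be read off, and a change of roughly that size either way, or none beyond the scatter, is the expectation. Compound 3 is estimated at 8 uL/min, within 3 uL/min to 25 uL/min, which means a 1.5-fold lower number from compound 2 to compound 3 (0.18 log units; within the scatter) is expected.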

Compound 3, intrinsic clearance in a liver preparation (reported as CLH), per the amount of preparation that the assay uses: 8 uL/min
The estimate for compound 3 equals the measured number at the digits printed, and the stated range covers the measured number.
By their numbers in this assay, from the lowest: compound 1; then compounds 3 and 2 (each within the scatter of the next).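

In this assay, the exchange of pyrazin-2-yl for 2-methylpyridin-4-yl on the sulfonyl sulfur, a 1.5-fold lower number from compound 2 to compound 3 (0.18 log units; within the scatter), shows that not every change of ring at this place moves the number beyond the scatter. Pyridazin-4-yl now stands apart from two different rings rather than one, with a 4.0-fold higher number from compound 1 to compound 3 (0.60 log units; beyond the scatter), so compound 1 keeps the lowest number of the three. Nothing available explains why these rings give these numbers.

The compounds shown leave open where a plain phenyl ring or an unsubstituted pyridin-4-yl would fall, and so what the methyl of 2-methylpyridin-4-yl contributes on its own. From the compounds shown here alone, it also remains unknown whether a saturated ring such as piperidine on the sulfonyl sulfur would stay close to compound 1 or to the other two.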